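Hydrazone aryl variation on a shared triazolyl-pyridine ether core

A few compounds are considered here, and "the series" means these few. Any claim that something is new, unique, unknown or untested is made for them only; others in the source may bear on it.

Compound 1 `CN(C)CCn1cnnc1-c1cc(Oc2ccc(NC(=O)N/N=C/c3ccc(O)c(Br)c3)cc2F)ccn1` carries a 3-bromo-4-hydroxyphenyl on the hydrazone carbon; in a functional assay on U-87MG ATCC cells (Homo sapiens) for cytotoxicity, read by MTT assay, with a stated time of 72 h (on this read-out lower numbers stand for stronger inhibition and higher numbers for weaker inhibition), compound 1 gives 12400 nM. Compound 2 `CN(C)CCn1cnnc1-c1cc(Oc2ccc(NC(=O)N/N=C/c3ccccc3O[N+](=O)[O-])cc2F)ccn1` replaces that aryl with 2-(nitrooxy)phenyl, and in this assay compound 2 gives 7150 nM. For the measured compounds named here, the only single-point step so far, a 1.7-fold lower number from compound 1 to compound 2 (0.24 log units; within the scatter), leaves the two within the scatter of one another, so no ordering between them is claimed. Compound 2 has the lowest of the two numbers recorded, with compound 1 as its nearest neighbour.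

Compound 3 `CN(C)CCn1cnnc1-c1cc(Oc2ccc(NC(=O)N/N=C/c3ccccc3)cc2F)ccn1` is the unsubstituted phenyl analogue; the change from compound 2 is hydrogen in place of nitrooxy on an aromatic carbon, on an aromatic carbon of a six-membered aromatic ring of carbon only, ortho to a large group. Going by the values given here, the one measured step that bears on it, a 1.7-fold lower number from compound 1 to compound 2 (0.24 log units; within the scatter), exchanged one substituted aryl for another at the same carbon and stayed within the scatter; nothing recorded isolates the nitrooxy group itself. A step of a 1.3-fold higher number from compound 2 to compound 3 (0.10 log units; within the scatter) is therefore expected, i.e. none beyond the scatter, and in this assay compound 3 is estimated at 9000 nM (range 3500 nM to 25000 nM).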

Compound 3, half-maximal inhibitory concentration: 2250 nM
Compound 3: the middle estimate sits 4.0-fold (0.60 log units) above what was measured, outside the stated range (below it).
By their numbers in this assay, from the lowest: compound 3; then compounds 2 and 1 (each within the scatter of the next).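

In this assay the aryl on the hydrazone carbon now shows a step that can be read: a 3.2-fold lower number from compound 2 to compound 3 (0.50 log units; beyond the scatter) for hydrogen in place of nitrooxy on an aromatic carbon, ortho to a large group, lies beyond the scatter, as the exchange between the two substituted aryls did not. The second comparison, a 5.5-fold lower number from compound 1 to compound 3 (0.74 log units; beyond the scatter) for phenyl in place of 3-bromo-4-hydroxyphenyl, also lies beyond the scatter, so compound 3 stands lowest of the three, while compound 1 and compound 2 remain unordered against each other. For the compounds shown here, both steps are modest, and across these three compounds each substituted aryl carries a higher number than the bare phenyl, with no compound going against this, although the pattern rests on only two substituted aryls.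

From the compounds shown here alone, whether the higher number of compound 1 belongs to its bromo or its hydroxy substituent cannot be separated, and whether a methoxy group, an amine or a carboxylic acid on this aromatic carbon would stay near compound 3 or move towards compound 2 remains open. No measurement at hand offers an explanation for these steps.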